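Swapping oxan-3-yl on the amide-type nitrogen: clearance notes

The compounds below may be only part of what the source reports. "The series", "measured", "known", "first", "only" and "open" are said of these compounds alone.

Measured so far in an in vitro ADME assay on microsomes (Homo sapiens) for metabolic stability; a higher number here means faster removal of the compound, a lower number slower removal:
- compound 1 `O=C(CN(C(=O)c1ccc(-n2ccnc2)cc1)C1CCCCC1)Nc1cc(F)cc(F)c1` gives 6.1 mL.min-1.g-1
- compound 2 `O=C(CN(C(=O)c1ccc(-c2ccccn2)cc1)C1CCCOC1)Nc1cc(F)cc(F)c1` gives 2.9 mL.min-1.g-1

Compound 2 holds the lower of the two numbers, and its gap to compound 1 lies beyond the scatter. Compound 3 `COCC(C)N(CC(=O)Nc1cc(F)cc(F)c1)C(=O)c1ccc(-c2ccccn2)cc1` is the next to be read, with 1-(methoxymethyl)ethyl in place of oxan-3-yl on an amide-type nitrogen. For the measured compounds named here, no measured pair isolates this change, so the starting point is compound 2 alone (2.9 mL.min-1.g-1). In this assay no shift beyond the scatter is expected, with a slight lean towards a higher number. The expected change (a 1.2-fold higher number from compound 2 to compound 3 (0.09 log units; within the scatter)) stays within the scatter. For compound 3 the estimated value is 3.6 mL.min-1.g-1 and the expected range runs from 1.7 mL.min-1.g-1 to 7.5 mL.min-1.g-1 on present evidence.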

Compound 3, intrinsic clearance in microsomes: 5.8 mL.min-1.g-1
The estimate for compound 3 lay 1.6-fold (0.21 log units) below the measured number, within the range that was stated.
By their numbers in this assay, from the lowest: compounds 2, 3 and 1 (each within the scatter of the next, the first and the last beyond it).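

In this assay, for the compounds shown here, the replacement of oxan-3-yl by 1-(methoxymethyl)ethyl on the amide-type nitrogen gives a 2.0-fold higher number from compound 2 to compound 3 (0.30 log units; within the scatter), the first step that isolates a single place. For this pair, the loss of the six-membered non-aromatic ring does not produce a separation beyond the scatter, so the data do not show that this ring sets the clearance reading at this position. Nothing measured here accounts for the size of this step.

On these data alone, whether the same holds for a longer ether chain or a ring carrying an amine, such as piperidin-4-yl, on this nitrogen remains open. Compound 1 differs from compound 2 and compound 3 in more than one place, so its number cannot be assigned to the group on this nitrogen alone.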